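From Aryl Amide to Piperidine Urea on a Shared Core

A few compounds are considered here, and "the series" means these few. Any claim that something is new, unique, unknown or untested is made for them only; others in the source may bear on it.

Of the compounds shown here, two on a shared core have been tested in an assay on HEK293 cells for positive allosteric modulation of metabotropic glutamate receptor 5 (Homo sapiens), read by FLIPR; on this read-out lower numbers stand for an effect already at smaller amounts and higher numbers for an effect only at larger amounts of compound. Compound 1 `Cc1ccc(S(=O)(=O)N2CC(c3nc(-c4cccc(Cl)c4)no3)C2)cc1` did not reach a measurable number: in this assay compound 1 gives > 10000 nM, which is a limit of the assay rather than a value. Compound 2 `O=C(c1ccc(F)cc1)N1CC(c2nc(-c3cccc(Cl)c3)no2)C1` stands the same way: in this assay compound 2 gives > 10000 nM, again a limit and not a number. Both measured values sit at this limit (the limit of > 10000 nM in this assay, at which 2 of the 2 values shown sit), so no step between measured compounds exists, and compound 2 cannot be placed apart from compound 1 on the numbers shown.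

Compound 3 `CC1CCN(C(=O)N2CC(c3nc(-c4cccc(Cl)c4)no3)C2)CC1` differs from compound 2 in one place: 4-methylpiperidin-1-yl in place of 4-fluorophenyl on a carbonyl carbon. Among the measured compounds shown here, with no measured step to lean on and both measured compounds at the limit, no shift beyond the usual scatter in this assay is expected from this change. The expected step from compound 2 to compound 3 is a step that the limit leaves unreadable from compound 2 to compound 3, estimated as small or none. Compound 3 is therefore expected to give about 15000 nM in this assay, within an estimated range from 5000 nM to 50000 nM, and most likely to be reported once more only as a limit.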

Compound 3, half-maximal effective concentration: 865 nM
For compound 3 the middle estimate is 17-fold (1.24 log units) above the measured one, and the stated range ends above it.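

In this assay, the place on the carbonyl carbon, whose other neighbour is an amide-type nitrogen in a ring, proves able to separate compounds on this shared core, which the earlier pair could not show. Exchanging 4-fluorophenyl for 4-methylpiperidin-1-yl gives an at least 11-fold lower number from compound 2 to compound 3 (1.06 log units; beyond the scatter), although both groups hold 7 heavy atoms and neither adds a hydrogen-bond donor, a hydrogen-bond acceptor or a net charge. This size is only a bound and not a full measure of the step, because compound 2 stands at a limit of the assay: the limit of > 10000 nM in this assay, at which 2 of the 3 values shown sit.

The single change replaces an aromatic carbon ring with a non-aromatic ring that holds a nitrogen and also brings in a methyl group, so the compounds shown do not tell which of these features goes with the step. On these data alone, it also remains open how an unsubstituted piperidine, a morpholine or a dimethylamino group would read at this place in this assay.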